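Chloro for butyl: expected effect on cell growth inhibition

A few compounds are considered here, and "the series" means these few. Any claim that something is new, unique, unknown or untested is made for them only; others in the source may bear on it.

Compound 1 `CCCCc1ccc(S(=O)(=O)NCCCCCCNCc2ccc(Br)cc2)cc1` has been measured in a functional assay on MIA PaCa-2 cells (Homo sapiens) for inhibition, read by MTT assay, with a stated time of 72 h (on this read-out higher numbers stand for weaker inhibition of growth and lower numbers for stronger inhibition of growth), where compound 1 gives 5700 nM, the highest of the two numbers in hand. Compound 2 `O=S(=O)(NCCCNCc1cccc(Cl)c1)c1cc(C(F)(F)F)cc(C(F)(F)F)c1` gives 4400 nM in this assay, a gap within the scatter, so the two stand level. Compound 3 `O=S(=O)(NCCCCCCNCc1ccc(Br)cc1)c1ccc(Cl)cc1` carries chloro in place of butyl on an aromatic carbon relative to compound 1. Among the compounds with values here, no measured pair shows this change, so the step is expected to be small, within the scatter, with no clear direction. Compound 3 is therefore estimated at 7000 nM in this assay, most likely between 3000 nM and 16000 nM. The expected step is a 1.2-fold higher number from compound 1 to compound 3 (0.09 log units; within the scatter), essentially nothing beyond the scatter.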

Compound 3, concentration for 50% growth inhibition: 5900 nM
Compound 3: the middle estimate sits 1.2-fold (0.07 log units) above what was measured; measured number inside the range.
By their numbers in this assay, from the lowest: compounds 2, 1 and 3 (each within the scatter of the next).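

In this assay, chloro in place of butyl on an aromatic carbon, para to a large group, gives a 1.0-fold higher number from compound 1 to compound 3 (0.01 log units; within the scatter). Within the data shown here, this is the first one-place comparison, and it shows that these two groups are interchangeable at this position on this read-out. Nothing in hand bears on the reason for this level result.

As far as these compounds go, whether an amine, a carboxylic acid or a longer chain on this aromatic carbon would keep the number level remains open. From the compounds shown here alone, it is also open whether the same swap would stay level on the core of compound 2.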